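Compound 1 to Compound 4: an Amide Substituent Swap

A few compounds are considered here, and "the series" means these few. Any claim that something is new, unique, unknown or untested is made for them only; others in the source may bear on it.

Compound 1, `COc1ccc2c(=O)c(/C=C/C(=O)Nc3cc(C)ccc3C)coc2c1`. In a functional assay on L02 cells (Homo sapiens) for inhibition, read by MTT assay, with a stated time of 48 h (a higher number here means a weaker inhibitor, a lower number a stronger inhibitor), compound 1 gives > 200000 nM, which is a limit of the assay.
Compound 2, `COc1ccc2c(=O)c(/C=C/C(=O)Nc3ccccc3C)coc2c1`. In this assay compound 2 gives > 200000 nM, a limit.
Compound 3, `COc1ccc2c(=O)c(/C=C/C(=O)Nc3ccc(F)cc3)coc2c1`. In this assay compound 3 gives > 200000 nM, a limit.

Compound 1 therefore stands only at a limit; no number places it, and the same holds for the two other compounds with the same core, as the shared limit shows: the limit of > 200000 nM in this assay, at which 3 of the 3 values shown sit. The steps that touch compound 1 are a step that the two limits leave unreadable from compound 1 to compound 2 and a step that the two limits leave unreadable from compound 1 to compound 3, and between the other two compounds a step that the two limits leave unreadable from compound 2 to compound 3. None of them can be read, so the measured compounds say nothing about how a change on the amide-type nitrogen moves the value.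

The unmeasured compound 4, `COc1ccc2c(=O)c(/C=C/C(=O)NCc3ccc(F)cc3F)coc2c1`, differs from compound 1 in one place: 2,4-difluorobenzyl in place of 2,5-dimethylphenyl on an amide-type nitrogen. With every measured step unreadable and every value at the limit, the most that can be expected is that compound 4 sits at the limit as well. Compound 4 is estimated at 200000 nM, with a range from 60000 nM to 400000 nM. The step this estimate means is a number no higher from compound 1 to compound 4 (the limit leaves the size open), expected to be no readable change.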

Compound 4, half-maximal inhibitory concentration: > 200000 nM
Compound 4 ended at the assay's limit; the forecaster's own chance of this, stated with the estimate: 80%; the middle value sits exactly at the limit.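

Compound 4 joins compound 1, compound 2 and compound 3 at a limit of the assay, so none of the steps from those three compounds to compound 4 can be read: the limit of > 200000 nM in this assay, at which 4 of the 4 values shown sit.

The compounds shown leave open whether any change on the amide-type nitrogen moves the value in this assay at all.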